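Acid dissociation across the shared core: notes on compound 4

The source may hold more compounds than are shown below. What is called first, only, known or untested is meant among the compounds shown, and "the series" means these compounds.

Measured compounds and their values in a physicochemical assay for acid dissociation:
compound 1, `COc1cccc(CNCCCNc2ccnc3cc(Oc4ccccc4)ccc23)c1O`, gives 9.28
compound 2, `COc1cccc(CNCCCNc2ccnc3cc(CCC(C)C)ccc23)c1O`, gives 9.47
compound 3, `COc1cccc(CNCCCNc2ccnc3cc(Cc4ccc(C#N)cc4)ccc23)c1O`, gives 9.47

Compound 3 sits level with compound 2 at the digits shown, the two together the highest of the three numbers; the remaining step is a number 0.19 log units higher from compound 1 to compound 3 (within the scatter), so all three lie within the scatter of one another.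

Compound 4 is `COc1ccccc1Oc1ccc2c(NCCCNCc3cccc(OC)c3O)ccnc2c1`. The change from compound 3 is 2-methoxyphenoxy in place of 4-cyanobenzyl on an aromatic carbon. Among the compounds with values here, the step that bears on it is the one from a phenoxy group to 4-cyanobenzyl, a number 0.19 log units higher from compound 1 to compound 3 (within the scatter), which was within the scatter; the change back towards a phenoxy group is therefore expected to move this assay by a number 0.17 log units lower from compound 3 to compound 4 (within the scatter), not beyond the scatter. Compound 4 is estimated at 9.3, with a range from 9 to 9.6.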

Compound 4, acid dissociation constant: 9.28
Compound 4: the middle estimate sits 0.02 log units above what was measured, and the stated range covers the measured number.
By their numbers in this assay, from the lowest: compounds 1, 4, 2 and 3 (each within the scatter of the next).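

In this assay, methoxy in place of hydrogen on an aromatic carbon of the phenoxy group gives no change at the digits printed from compound 1 to compound 4 (within the scatter). At this position, 2-methoxyphenoxy in place of 4-cyanobenzyl gives a number 0.19 log units lower from compound 3 to compound 4 (within the scatter), and in place of isopentyl it gives a number 0.19 log units lower from compound 2 to compound 4 (within the scatter), so the aryl ether, benzyl and saturated chain groups shown all stay within the scatter of one another. No supporting evidence bears on this result. Going by these compounds, whether an amine or a carboxylic acid at this position would give a step beyond the scatter remains open.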